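The source may report more compounds than this note shows. Statements on the series, on what has been measured and on what is new or still open speak of the compounds shown alone.

Of the compounds shown here, two built on a shared core have been measured in a functional assay on WiDr cells (Homo sapiens) for antiproliferative activity, read by sulforhodamine B assay, with a stated time of 48 h; on this read-out lower numbers stand for stronger inhibition of growth and higher numbers for weaker inhibition of growth. Compound 1 `CSc1nc(NCc2ccccc2)c2c(n1)C(=O)C(c1ccccc1)=[N+]2[O-]` gives 79000 nM in that assay. Compound 2 `Nc1nc(NCc2ccccc2)nc2c1[N+]([O-])=C(c1ccccc1)C2=O` gives 24000 nM, the lower of the two numbers, and its gap to compound 1 lies beyond the scatter of repeated measurements. Compound 3 `Nc1nc(NCCN2CCCC2)nc2c1[N+]([O-])=C(c1ccccc1)C2=O` has not yet been measured. It differs from compound 2 in a single place: (pyrrolidin-1-yl)methyl in place of phenyl on a saturated chain carbon bound to a nitrogen on an aromatic ring. Within the data shown here, no pair of measured compounds shows this change, so the numbers at hand supply no step to lean on, and the expectation rests only on compound 2 as the starting point. The step is expected to be small, a 1.2-fold lower number from compound 2 to compound 3 (0.08 log units; within the scatter), and may well be none beyond the scatter, in either direction. In this assay compound 3 is estimated at 20000 nM, with a range from 5000 nM to 80000 nM.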

Compound 3, concentration for 50% growth inhibition: 14000 nM
The estimate for compound 3 lay 1.4-fold (0.15 log units) above the measured number; low and high end bracket the measured number.
By their numbers in this assay, from the lowest: compounds 3 and 2 (each within the scatter of the next); then compound 1.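

In this assay, replacing benzyl with 2-(pyrrolidin-1-yl)ethyl on the ring nitrogen gives a 1.7-fold lower number from compound 2 to compound 3 (0.23 log units; within the scatter), so the two compounds cannot be told apart on this read-out. At this position, then, an aromatic carbon ring at the end of the side chain can give way to a non-aromatic five-membered ring containing nitrogen without any difference that this measurement can resolve. No measured evidence here speaks to why the two groups read alike.

The compounds shown leave open how chain length and ring type each contribute, which 2-phenylethyl, 3-(pyrrolidin-1-yl)propyl or 2-(piperidin-1-yl)ethyl at the same place could begin to separate. Going by these compounds, it also remains open whether the same exchange would read alike on the core of compound 1.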